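Thiophene Swapped for Bromophenyl on the Shared Core

The source may report more compounds than this note shows. Statements on the series, on what has been measured and on what is new or still open speak of the compounds shown alone.

Compound 2 `c1cn2cc(-c3ccsc3)nc(-c3ccc4ncn(C5CCCCC5)c4c3)c2n1` holds the lower of the two numbers measured in a functional assay on LOX IMVI cells (Homo sapiens) for inhibition, read by sulforhodamine B assay, with a stated time of 48 h, tested at 10 uM (on this read-out lower numbers stand for less inhibition and higher numbers for more inhibition at the one concentration tested (going by the name of the read-out)), where compound 2 gives 4.9%. Among the compounds with values here, compound 1 `Brc1cn2ccnc2c(-c2ccc3ncn(C4CCCCC4)c3c2)n1` carries bromo at the same aromatic carbon and in this assay compound 1 gives 15.2%; the only measured step, a number 10.3 percentage points lower from compound 1 to compound 2 (beyond the scatter), took the number down modestly. Compound 3 `Brc1ccc(-c2cn3ccnc3c(-c3ccc4ncn(C5CCCCC5)c4c3)n2)cc1` differs from compound 2 by 4-bromophenyl in place of thiophen-3-yl on an aromatic carbon. Within the data shown here, no measured step describes a 4-bromophenyl at this place, so the only step that bears on it, and only loosely, is a number 10.3 percentage points lower from compound 1 to compound 2 (beyond the scatter), where an aryl replaced a halogen. For compound 3 the step of a number 4.1 percentage points higher from compound 2 to compound 3 (within the scatter) is therefore expected to be small, within or barely beyond the scatter, leaning slightly upward. Compound 3 is estimated to give 9%, within a range from -4% to 25%.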

Compound 3, a percentage reported as inhibition, at one concentration (the size of the read-out at that concentration, not a potency): 30.7%
Compound 3: the middle estimate sits 21.7 percentage points below what was measured; measured number outside the range, above it.
By their numbers in this assay, from the lowest: compound 2; then compound 1; then compound 3.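

In this assay, the move to 4-bromophenyl at this aromatic carbon gives a number 25.8 percentage points higher from compound 2 to compound 3 (beyond the scatter) and, against the bromo compound, a number 15.5 percentage points higher from compound 1 to compound 3 (beyond the scatter). Set beside a number 10.3 percentage points lower from compound 1 to compound 2 (beyond the scatter), this shows that replacing bromo with an aromatic ring at this place can move the number either down or up, depending on which ring enters. Nothing measured here explains why thiophen-3-yl and 4-bromophenyl part in this way.

Since 4-bromophenyl differs from thiophen-3-yl both in its ring and in carrying bromine, the compounds shown do not separate the two changes. On these data alone, it remains open what a plain phenyl would give at this place, and whether an amine or a carboxylic acid on that ring would keep the higher number.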